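Losing the ring from the ether group

A few compounds are considered here, and "the series" means these few. Any claim that something is new, unique, unknown or untested is made for them only; others in the source may bear on it.

For the measured compounds named here, in a functional assay on HMEC-1 cells (Homo sapiens) for antiproliferative activity, read by cell counting, with a stated time of 4 days (on this read-out higher numbers stand for weaker inhibition and lower numbers for stronger inhibition), compound 1 (`CC(Nc1ccccc1Oc1ccc(Cl)cc1)=C1C(=O)CC(c2ccccc2)CC1=O`) gives 260 nM, and compound 2 (`COc1cc(Oc2ccccc2NC(C)=C2C(=O)CC(c3ccccc3)CC2=O)ccc1N`) gives 29 nM, the lower of the two numbers so far. Compound 3 (`CCOc1ccccc1NC(C)=C1C(=O)CC(c2ccccc2)CC1=O`) differs from compound 2 by ethyl in place of 4-amino-3-methoxyphenyl on an oxygen on an aromatic ring, with ethyl in place of 4-amino-3-methoxyphenyl on an oxygen on an aromatic ring. Going by the values given here, the only measured step, a 9.0-fold lower number from compound 1 to compound 2 (0.95 log units; beyond the scatter), changed this same place but kept a six-membered aromatic ring there, so it shows sensitivity without sizing a loss of that ring. The expected change, a rise in the number, is a 41-fold higher number from compound 2 to compound 3 (1.62 log units; beyond the scatter). The estimate for compound 3 is 1200 nM, with an expected range of 200 nM to 7000 nM.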

Compound 3, half-maximal inhibitory concentration: 100 nM
The estimate for compound 3 lay 12-fold (1.08 log units) above the measured number; the whole stated range lies above it.
By their numbers in this assay, from the lowest: compound 2; then compound 3; then compound 1.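

Ethyl on this oxygen shows that a six-membered aromatic ring is not required for activity in this assay, although replacing 4-amino-3-methoxyphenyl still gives a 3.4-fold higher number from compound 2 to compound 3 (0.54 log units; beyond the scatter). Replacing 4-chlorophenyl with ethyl gives a 2.6-fold lower number from compound 1 to compound 3 (0.41 log units; beyond the scatter), so the presence of the ring alone does not set the order of these three compounds. No available evidence bears on this order. Open, as far as these compounds go, is whether the lower number of compound 2 depends on the amino group, the methoxy group or both. Also open, from the compounds shown here alone, is how a butyl chain or an unsubstituted phenyl ring on this oxygen would compare.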